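Shortening the ethyl chain of compound 3

The source may report more compounds than this note shows. Statements on the series, on what has been measured and on what is new or still open speak of the compounds shown alone.

In a functional assay for inhibition, with Rattus norvegicus as the target (on this read-out higher numbers stand for weaker inhibition and lower numbers for stronger inhibition), compound 3 (`CCCCc1c(CC)c(OC)c2ccccc2c1OC(C)=O`) gives 990 nM, the lowest of the three numbers, against compound 1 (`CCOC(=O)c1c(CC)c(OC)c2ccccc2c1OC(C)=O`) at 3760 nM and compound 2 (`CCCCc1c(CCCC)c(OC(C)=O)c2ccccc2c1OC`) at 6020 nM. Compound 4 (`CCCCc1c(C)c(OC)c2ccccc2c1OC(C)=O`) differs from compound 3 by hydrogen in place of methyl on a saturated chain carbon bound to an aromatic carbon, or ethyl to methyl. The nearest guide is a 6.1-fold lower number from compound 2 to compound 3 (0.78 log units; beyond the scatter), where hydrogen replaces ethyl on a chain. The step of a 3.8-fold lower number from compound 1 to compound 3 (0.58 log units; beyond the scatter) changes a different group and bears only weakly. A smaller step in the same direction is expected, possibly within the scatter: a 1.2-fold lower number from compound 3 to compound 4 (0.09 log units; within the scatter). Compound 4 is estimated at 800 nM, with an expected range of 300 nM to 2200 nM.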

Compound 4, half-maximal inhibitory concentration: 200 nM
The estimate for compound 4 lay 4.0-fold (0.60 log units) above the measured number; measured number below the stated range.
By their numbers in this assay, from the lowest: compound 4; then compound 3; then compounds 1 and 2 (each within the scatter of the next).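

In this assay, ethyl to methyl on this carbon gives a 5.0-fold lower number from compound 3 to compound 4 (0.69 log units; beyond the scatter), so a single carbon less on this chain moves the number beyond the scatter. With a 30-fold lower number from compound 2 to compound 4 (1.48 log units; beyond the scatter), the number falls at each shortening of this chain from compound 2 through compound 3 to compound 4, and none of the three goes against this. No evidence here accounts for the size of the change.

From the compounds shown here alone, whether the trend continues with a hydroxymethyl group or an amine at this position remains open. So does whether methyl gives a similar step with ethoxycarbonyl in place of butyl.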